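The source may hold more compounds than are shown below. What is called first, only, known or untested is meant among the compounds shown, and "the series" means these compounds.

In a functional assay on DU-145 cells (Homo sapiens) for inhibition, read by trypan blue exclusion, with a stated time of 96 h (on this read-out higher numbers stand for weaker inhibition of growth and lower numbers for stronger inhibition of growth), compound 1 `COc1cc(OC)c(/C=C(\C(=O)c2ccc(Br)cc2)S(=O)(=O)c2ccc(Br)cc2)c(OC)c1` gives > 100000 nM, which is a limit of the assay and not a number. Compound 2 `COc1cc(OC)c(/C=C(\C(=O)c2ccc(Cl)cc2)S(=O)(=O)c2ccc(Br)cc2)c(OC)c1` gives > 100000 nM, again only a limit. This puts compound 2 at the limit of > 100000 nM in this assay, at which 2 of the 3 values shown sit, so its true standing is not known. Compound 3 `Cc1ccc(S/C(=C/c2c[nH]c3ccc(Cl)cc23)C(=O)c2ccc(Cl)cc2)cc1`, which differs from both in several places, gives 1000 nM in this assay.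

The change under consideration leads to compound 4 `COc1cc(OC)c(/C=C(\C(=O)c2ccc(Cl)cc2)S(=O)(=O)Cc2ccc(F)cc2)c(OC)c1`: 4-fluorobenzyl in place of 4-bromophenyl on a sulfonyl sulfur. Thus 4-fluorobenzyl stands in place of 4-bromophenyl on a sulfonyl sulfur. Among the measured compounds shown here, the only measured step, a step that the two limits leave unreadable from compound 1 to compound 2, is chloro in place of bromo on an aromatic carbon. It gives no size to carry over and does not touch the sulfonyl sulfur, so the expectation rests on little. Since compound 2 gives > 100000 nM, a measurable result could only lie on the side of stronger inhibition of growth, and a second limit remains quite possible. The expected change is an at least 33-fold lower number from compound 2 to compound 4 (1.52 log units; beyond the scatter), and its size is uncertain. The estimated value for compound 4 is 3000 nM, with an expected range from 100 nM to 100000 nM.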

Compound 4, concentration for 50% growth inhibition: 25000 nM
For compound 4 the middle estimate is 8.3-fold (0.92 log units) below the measured one; low and high end bracket the measured number.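

In this assay compound 2 gives > 100000 nM, which is a limit of the assay and not a number. Against that limit, the sulfonyl sulfur proves to be a place where a single change yields a readable result: 4-fluorobenzyl in place of 4-bromophenyl gives an at least 4.0-fold lower number from compound 2 to compound 4 (0.60 log units; beyond the scatter). The step from compound 1 to compound 2 cannot be read, so this is the first step in the series with any size, and that size is only a lower bound on the true change, as the standing of compound 2 remains unresolved: the limit of > 100000 nM in this assay, at which 2 of the 4 values shown sit.

The change replaces the halogen and adds a carbon between the ring and the sulfonyl sulfur in one move, so the compounds shown do not tell which of the two carries the gain; 4-fluorophenyl or 4-bromobenzyl on the sulfonyl sulfur would separate them. As far as these compounds go, it also remains open whether a longer chain there, such as 2-phenylethyl, or a ring-bearing amine would move the number further in the same direction.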